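The source may hold more compounds than are shown below. What is called first, only, known or untested is meant among the compounds shown, and "the series" means these compounds.

In an in vitro ADME assay on microsomes from liver (Mus musculus, strain CD1) for metabolic stability, read by HPLC, with a stated time of 4 h (on this read-out higher numbers stand for fast clearance and lower numbers for slow clearance), compound 1 (`CCOC(=O)c1c(-c2cccc(-c3ccccc3)c2)[nH]c2cc(OC)ccc2c1=O`) stands at 5.7 mL.min-1.g-1 and compound 2 (`CCOC(=O)c1c(-c2cccc(OCC)c2)[nH]c2cc(OC)ccc2c1=O`) at 12 mL.min-1.g-1 while compound 3 (`CCOC(=O)c1c(-c2cccc(Oc3ccccc3)c2)[nH]c2cc(OC)ccc2c1=O`) at 35 mL.min-1.g-1 has the highest of the three numbers. Compound 4 (`CCOC(=O)c1c(-c2cccc(Oc3ccccc3)c2)[nH]c2cc(OC)c(F)cc2c1=O`) differs from compound 3 in one place (fluoro in place of hydrogen on an aromatic carbon), with fluoro in place of hydrogen on an aromatic carbon. Among the measured compounds shown here, no measured step involves fluoro or touches that carbon, so the data give no direct guide and only a rough sense of how far one change can move this assay in this small set. Ethoxy in place of phenyl gives a 2.1-fold higher number from compound 1 to compound 2 (0.32 log units; beyond the scatter) while phenoxy in place of phenyl gives a 6.1-fold higher number from compound 1 to compound 3 (0.79 log units; beyond the scatter) and phenyl in place of ethyl on an oxygen gives a 2.9-fold higher number from compound 2 to compound 3 (0.46 log units; beyond the scatter) as the third modest step. Each of those swaps exchanges one whole group for another, whereas here only a hydrogen is replaced. So a 1.2-fold lower number from compound 3 to compound 4 (0.07 log units; within the scatter) is the expected step, one within the scatter and with no firm direction. The estimate for compound 4 is 30 mL.min-1.g-1 and the expected range runs from 14 mL.min-1.g-1 to 65 mL.min-1.g-1 on this read-out.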

Compound 4, intrinsic clearance in microsomes: 16 mL.min-1.g-1
For compound 4 the middle estimate is 1.9-fold (0.27 log units) above the measured one, and the stated range covers the measured number.
By their numbers in this assay, from the lowest: compound 1; then compounds 2 and 4 (each within the scatter of the next); then compound 3.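

In this assay, putting fluoro in place of hydrogen gives a 2.2-fold lower number from compound 3 to compound 4 (0.34 log units; beyond the scatter) and so moves the number beyond the scatter, even though only one heavy atom enters. Among the compounds shown here, this is the first measured change on this aromatic carbon, ortho to a methoxy group, and it shows that the carbon is not a silent place on the shared core: here the change goes toward slower clearance. Nothing available explains why the number moves in this way.

As far as these compounds go, the step is known only alongside the phenoxy group of compound 3, so it remains open whether fluoro would act alike alongside the phenyl group of compound 1 or the ethoxy group of compound 2. From the compounds shown here alone, it is also open whether chloro, methyl or a nitrile on the same carbon would shift the number as far.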